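Adding fluoro to compound 3

The source may hold more compounds than are shown below. What is called first, only, known or untested is meant among the compounds shown, and "the series" means these compounds.

In a functional assay on HCT-116 cells (Homo sapiens) for cytotoxicity, with a stated time of 48 h (a lower number here means a stronger inhibitor, a higher number a weaker inhibitor), compound 3 (`COc1cc(OC)c(C(=O)/C=C/c2ccccc2)c(OC)c1`) gives 6900 nM. This value lies within the scatter of the values for compound 2 (`COc1cc(OC)c(C(=O)/C=C/c2ccccc2SC)c(OC)c1`), at 6800 nM, and compound 1 (`COc1cc(O)c(C(=O)/C=C/c2ccc(F)cc2)c(OC)c1`), at 12400 nM, so the three compounds cannot be ranked.

Compound 4 (`COc1cc(OC)c(C(=O)/C=C/c2ccc(F)cc2)c(OC)c1`) has fluoro in place of hydrogen on an aromatic carbon of compound 3, para to a large group: fluoro in place of hydrogen on an aromatic carbon. Going by the values given here, the only measured step that bears on this change is also a replacement on an aromatic carbon, a 1.0-fold higher number from compound 2 to compound 3 (0.01 log units; within the scatter), but it involves methylsulfanyl rather than fluoro. Among the compounds with values here, compound 1 also carries 4-fluorophenyl, but its core differs, so no measured pair isolates the fluoro change. No shift beyond the scatter is therefore expected in this assay, in either direction. The expected step is a 1.1-fold higher number from compound 3 to compound 4 (0.04 log units; within the scatter). For compound 4, the estimated value is 7500 nM, with an expected range of 3800 nM to 14000 nM.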

Compound 4, half-maximal inhibitory concentration: 6200 nM
Compound 4: middle estimate off by 1.2-fold (0.08 log units), on the high side; measured number inside the range.
By their numbers in this assay, from the lowest: compounds 4, 2, 3 and 1 (each within the scatter of the next).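

Fluoro in place of hydrogen, para to a large group, gives a 1.1-fold lower number from compound 3 to compound 4 (0.05 log units; within the scatter) in this assay, the first direct reading of this change on the shared core, and the step stays within the scatter. The exchange of 2-(methylsulfanyl)phenyl for 4-fluorophenyl gives a 1.1-fold lower number from compound 2 to compound 4 (0.04 log units; within the scatter) and is also within the scatter, so hydrogen, 2-(methylsulfanyl) and 4-fluoro on the phenyl ring of compound 2, compound 3 and compound 4 cannot be told apart here. With 4-fluorophenyl held constant, methyl in place of hydrogen on an oxygen on an aromatic ring gives a 2.0-fold lower number from compound 1 to compound 4 (0.30 log units; within the scatter) and likewise remains within the scatter.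

On these data alone, whether an amine, a carboxylic acid or a longer chain at this position would move the number beyond the scatter remains open. No available data give a reason for any of these steps.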